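The source may hold more compounds than are shown below. What is called first, only, known or untested is meant among the compounds shown, and "the series" means these compounds.

Compound 1 `CC(O)(CSc1cccc(C(F)(F)F)c1)C(=O)Nc1cccc(S(F)(F)(F)(F)F)c1` is the starting point of this set. In a functional assay on CWR22R cells (Homo sapiens) for antiproliferative activity, read by propidium iodide staining, with a stated time of 96 h (a higher number here means a weaker inhibitor, a lower number a stronger inhibitor), compound 1 gives 12900 nM. Compound 2 `CC(O)(CSc1ccccc1C(F)(F)F)C(=O)Nc1cccc(S(F)(F)(F)(F)F)c1` carries the change (2-(trifluoromethyl)phenyl in place of 3-(trifluoromethyl)phenyl on a sulfur), and in this assay compound 2 gives 13200 nM, so that the change made a 1.0-fold higher number from compound 1 to compound 2 (0.01 log units; within the scatter).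

Compound 3 `CC(O)(CS(=O)(=O)c1cccc(C(F)(F)F)c1)C(=O)Nc1ccc(S(F)(F)(F)(F)F)cc1` has a different core; how its core differs from that of compound 1 is not broken down here. In this assay compound 3 gives 23800 nM.

Compound 4 `CC(O)(CS(=O)(=O)c1ccccc1C(F)(F)F)C(=O)Nc1ccc(S(F)(F)(F)(F)F)cc1` is not yet measured. It differs from compound 3 by 2-(trifluoromethyl)phenyl in place of 3-(trifluoromethyl)phenyl on a sulfonyl sulfur. This is the same kind of change as that from compound 1 to compound 2, though not the same: there the group sat on a sulfur whose other neighbours are a saturated chain carbon, here it sits on a sulfonyl sulfur whose other neighbours are a saturated chain carbon. Resting on the step of a 1.0-fold higher number from compound 1 to compound 2 (0.01 log units; within the scatter), the step from compound 3 to compound 4 is expected to be a 1.0-fold higher number from compound 3 to compound 4 (0.00 log units; within the scatter). Compound 4 is therefore estimated at 24000 nM, between 12000 nM and 50000 nM.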

Compound 4, half-maximal inhibitory concentration: 17400 nM
Compound 4: the middle estimate sits 1.4-fold (0.14 log units) above what was measured; the measured number falls inside the stated range.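

In this assay, 2-(trifluoromethyl)phenyl in place of 3-(trifluoromethyl)phenyl on a sulfonyl sulfur gives a 1.4-fold lower number from compound 3 to compound 4 (0.14 log units; within the scatter). Set beside the same change on a sulfur, the new step does not differ from the earlier one: the same change on two cores in this assay, a 1.0-fold higher number (0.01 log units; within the scatter) from compound 1 to compound 2 and a 1.4-fold lower number (0.14 log units; within the scatter) from compound 3 to compound 4, 1.4-fold (0.15 log units) apart, within the scatter of two such steps

Within these two pairs, then, the change carries from one core to the other in a limited sense: on neither core does it move the number beyond the scatter, and the two steps agree. This does not show that the two groups are interchangeable on other cores, and, since neither step exceeds the scatter, it does not show that a change of real size would carry over.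

The compounds shown leave open how a 4-(trifluoromethyl)phenyl group would compare with these two. As far as these compounds go, it also remains open whether a nitrile or a chlorine in place of the trifluoromethyl group would behave in the same way on both cores.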